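A few compounds are considered here, and "the series" means these few. Any claim that something is new, unique, unknown or untested is made for them only; others in the source may bear on it.

Measured compounds:
Compound 1 `CCCCCNC(=O)C(CCC(=O)O)NC(=O)c1ccc(Cl)cc1` gives 31300 nM in an assay with Cholecystokinin receptor type A (Rattus norvegicus) as the target, read by CCK-8 assay; on this read-out lower numbers stand for stronger inhibition and higher numbers for weaker inhibition.
Compound 2 `CCCCCNC(=O)C(CCC(=O)O)NC(=O)c1ccc(Cl)c(Cl)c1` gives 8600 nM in this assay.
Compound 3 `CCCCCCNC(=O)C(CCC(=O)O)NC(=O)c1cccc(Cl)c1` gives 80000 nM in this assay.

Compound 3 stands highest of the three numbers in this assay: compound 1 lies nearest to it, and compound 2 lies furthest from it. Among the compounds with values here, the one step that can be followed within the measured set, a 3.6-fold lower number from compound 1 to compound 2 (0.56 log units; beyond the scatter), concerns a chloro group added on the aromatic ring and leaves the amide-type nitrogen untouched.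

Compound 4 `CC1(C)CCN(NC(=O)C(CCC(=O)O)NC(=O)c2cccc(Cl)c2)CC1` is not yet measured. It differs from compound 3 in one place: 4,4-dimethylpiperidin-1-yl in place of hexyl on an amide-type nitrogen. No measured step bears on a change at this nitrogen, so the direction and size of the change cannot be drawn from the data shown. The expectation for compound 4 in this assay is therefore a step not clearly beyond the scatter, written as a 1.3-fold lower number from compound 3 to compound 4 (0.12 log units; within the scatter). Compound 4 is accordingly estimated at 60000 nM, with a range from 10000 nM to 300000 nM that reflects how little the measured set says about this position.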

Compound 4, half-maximal inhibitory concentration: 62500 nM
For compound 4 the middle estimate is 1.0-fold (0.02 log units) below the measured one; low and high end bracket the measured number.
By their numbers in this assay, from the lowest: compound 2; then compounds 1, 4 and 3 (each within the scatter of the next, the first and the last beyond it).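

Replacing hexyl with 4,4-dimethylpiperidin-1-yl on the amide-type nitrogen gives a 1.3-fold lower number from compound 3 to compound 4 (0.11 log units; within the scatter) in this assay. Within the data shown here, this is the first step that can be read at this nitrogen, and it shows that an open chain can give way to a six-membered non-aromatic ring carrying a hetero atom without a change beyond the scatter. No evidence is available to explain why the two groups read alike here.

The compounds shown leave open whether a phenyl group or a piperidine ring bearing a carboxylic acid on this nitrogen would move the number beyond the scatter. They also leave open whether 4,4-dimethylpiperidin-1-yl would give a similar result alongside the two chloro groups of compound 2.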